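Side-chain variation on a shared core: outlook for compound 4

A few compounds are considered here, and "the series" means these few. Any claim that something is new, unique, unknown or untested is made for them only; others in the source may bear on it.

Measured so far in a functional assay for inhibition; a higher number here means a weaker inhibitor, a lower number a stronger inhibitor:
compound 1 `CC(C)(C)c1cc(-c2cc(=O)c3ccc(OCC(=O)N4CCN(Cc5ccccc5)CC4)cc3o2)cc(C(C)(C)C)c1O` gives 3000 nM
compound 2 `CC(C)(C)c1cc(-c2cc(=O)c3ccc(OCCO)cc3o2)cc(C(C)(C)C)c1O` gives 3000 nM
compound 3 `CC(C)(C)c1cc(C(=O)Oc2ccc3c(=O)cc(-c4cc(C(C)(C)C)c(O)c(C(C)(C)C)c4)oc3c2)cc(C(C)(C)C)c1O` gives 30000 nM

In this assay compound 2 stands level with compound 1 at the digits shown, and the two together give the lowest numbers of the three; compound 3 lies beyond the scatter above both. The chains on the oxygen on the aromatic ring of compound 1 and compound 2 differ widely yet the numbers agree, so this position appears tolerant within the data shown.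

Compound 4 `CCOC(=O)COc1ccc2c(=O)cc(-c3cc(C(C)(C)C)c(O)c(C(C)(C)C)c3)oc2c1` differs from compound 2 as follows: ethoxycarbonyl in place of hydroxymethyl on a saturated chain carbon bound to an oxygen on an aromatic ring. Going by the values given here, no measured pair covers this change. Compound 4 is expected to show no step beyond the scatter, no change at the digits printed from compound 2 to compound 4 (within the scatter). Compound 4 is estimated at 3000 nM, with a range from 1000 nM to 10000 nM.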

Compound 4, half-maximal inhibitory concentration: 3000 nM
Estimate against measurement, compound 4: no gap at the digits printed; the measured number falls inside the stated range.
By their numbers in this assay, from the lowest: compounds 1, 2 and 4 (each within the scatter of the next); then compound 3.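

In this assay, ethoxycarbonyl in place of hydroxymethyl on a saturated chain carbon bound to an oxygen on an aromatic ring gives no change at the digits printed from compound 2 to compound 4 (within the scatter). Going by these compounds alone, this is the first single-place step at this position, and it shows that the number holds when the hydrogen-bond donor of hydroxymethyl is absent and the group grows to 5 heavy atoms. No evidence on hand accounts for this flat step. Still open, on these data alone, is whether a carboxylic acid in place of the ethoxycarbonyl, or an amine on the same chain, would keep the number level. Also open, as far as these compounds go, is whether any chain on this oxygen can move it beyond the scatter.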